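The source may hold more compounds than are shown below. What is called first, only, known or untested is meant among the compounds shown, and "the series" means these compounds.

Compound 1 `CN1C/C(=C\c2ccncc2)C(=O)/C(=C/c2ccccc2C(F)(F)F)C1`: 3300 nM
Compound 2 `O=C1/C(=C/c2ccncc2)CNC/C1=C\c1ccccc1F`: 8200 nM
Compound 3 `O=C1/C(=C/c2cccnc2)CNC/C1=C\c1ccccc1C(F)(F)F`: 5020 nM

All three compounds have been tested in a functional assay on HepG2 cells (Homo sapiens) for cytotoxicity, read by MTT assay, with a stated time of 24 h; on this read-out higher numbers stand for weaker inhibition and lower numbers for stronger inhibition. On this scale, compound 3, at 5020 nM, lies within the usual scatter of both compound 1 and compound 2, so these numbers cannot separate it from either one.

The next compound, compound 4 `O=C1/C(=C/c2ccncc2)CNC/C1=C\c1ccccc1C(F)(F)F`, has not yet been measured. It contains the same atoms as compound 3, joined differently: pyridin-4-yl stands in place of pyridin-3-yl on a double-bonded chain carbon bound to a double-bonded ring carbon (pyridin-4-yl in place of pyridin-3-yl on a double-bonded chain carbon bound to a double-bonded ring carbon). For the measured compounds named here, no measured pair shows this change on its own, so the data offer no direct guide to its size. Going by the values given here, the only indirect guide comes from two compounds that already carry pyridin-4-yl: compound 1 gives 3300 nM and compound 2 gives 8200 nM. Both values stay within the scatter of compound 3, so no shift beyond the scatter is expected in this assay. The estimated change is a 1.2-fold lower number from compound 3 to compound 4 (0.07 log units; within the scatter), which is too small to give a confident direction. For compound 4, the expected value is 4300 nM, with an estimated range from 2000 nM to 9000 nM.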

Compound 4, half-maximal inhibitory concentration: 6130 nM
Compound 4: middle estimate off by 1.4-fold (0.15 log units), on the low side, within the range that was stated.
By their numbers in this assay, from the lowest: compounds 1, 3, 4 and 2 (each within the scatter of the next, the first and the last beyond it).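

In this assay the swap of pyridin-3-yl for pyridin-4-yl on a double-bonded chain carbon bound to a double-bonded ring carbon can now be read on its own: a 1.2-fold higher number from compound 3 to compound 4 (0.09 log units; within the scatter) shows that the two pyridine groups cannot be told apart at this place. For the compounds shown here, compound 4 also gives the first single-place readings of two other changes, with trifluoromethyl in place of fluoro on an aromatic carbon giving a 1.3-fold lower number from compound 2 to compound 4 (0.13 log units; within the scatter) and hydrogen in place of methyl on an amine nitrogen in a ring giving a 1.9-fold higher number from compound 1 to compound 4 (0.27 log units; within the scatter) as its step. All three single changes therefore stay within the scatter on this cytotoxicity read-out, and no further measurement is available that could help to interpret them.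

The compounds shown leave open whether pyridin-2-yl or a plain phenyl group at this place would give a step beyond the scatter. They also leave open whether a benzyl or acetyl group on the ring nitrogen, or a carboxylic acid on the aromatic ring, would separate from these compounds.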